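A few compounds are considered here, and "the series" means these few. Any claim that something is new, unique, unknown or untested is made for them only; others in the source may bear on it.

Measured compounds, all in a functional assay on CHO cells for antagonist activity at Orexin/Hypocretin receptor type 1 (Homo sapiens), read by FLIPR and calcium flux; a higher number here means a more potent compound, by a factor of ten per unit of this negative logarithm, a lower number a less potent compound:
- compound 1 `Cc1cc(C(F)(F)F)cc(NC[C@@H]2CC3(CC3)CN2C(=O)c2nc(C)sc2-c2ccccc2)n1`, which gives 7.8
- compound 2 `Cc1nc(C(=O)N2CC3(CC3)C[C@H]2CNc2cc(C(F)(F)F)ccn2)c(-c2ccccc2)s1`, which gives 8.2
- compound 3 `Cc1nc(C(=O)N2CC3(CC3)C[C@H]2CNc2ncc(Cl)cn2)c(-c2ccccc2)s1`, which gives 6.8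

Compound 3 stands lowest of the three. Its nearest neighbour is compound 1, and the change was a number 1.00 log units lower from compound 1 to compound 3 (beyond the scatter); the gap to compound 2 is wider still, as a number 1.40 log units lower from compound 2 to compound 3 (beyond the scatter). Both of these steps swap the group on the amine nitrogen, and in both the 5-chloropyrimidin-2-yl group comes with a lower number than a pyridine carrying a trifluoromethyl group.

Compound 4 `Cc1nc(C(=O)N2CC3(CC3)C[C@H]2CNc2ccc(C(F)(F)F)cn2)c(-c2ccccc2)s1` reverses that kind of swap. Compared with compound 3, the difference is 5-(trifluoromethyl)pyridin-2-yl in place of 5-chloropyrimidin-2-yl on an amine nitrogen. The entering group is again a pyridine with a trifluoromethyl group, though the trifluoromethyl sits at a different place on the ring than in compound 1 or compound 2, so the two earlier steps are a guide rather than an exact match. Given a number 1.40 log units lower from compound 2 to compound 3 (beyond the scatter) and a number 1.00 log units lower from compound 1 to compound 3 (beyond the scatter), an increase beyond the scatter is expected in this assay, estimated as a number 0.90 log units higher from compound 3 to compound 4 (beyond the scatter). Compound 4 is therefore expected to give about 7.7, with a range from 7 to 8.4.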

Compound 4, negative logarithm of the antagonist equilibrium constant: 8.4
The estimate for compound 4 lay 0.70 log units below the measured number, within the range that was stated.
By their numbers in this assay, from the lowest: compound 3; then compound 1; then compounds 2 and 4 (each within the scatter of the next).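

In this assay, replacing the 5-chloropyrimidin-2-yl group on the amine nitrogen with 5-(trifluoromethyl)pyridin-2-yl gives a large rise (a number 1.60 log units higher from compound 3 to compound 4 (beyond the scatter)), so this position responds strongly to the choice of aromatic group. The trifluoromethyl group can also stand at a different place on the pyridine without a measurable change, as 5-(trifluoromethyl)pyridin-2-yl and 4-(trifluoromethyl)pyridin-2-yl cannot be told apart (a number 0.20 log units higher from compound 2 to compound 4 (within the scatter)). Compound 1, whose 6-methyl-4-(trifluoromethyl)pyridin-2-yl group is the only one here with a methyl on the ring, now stands below this second pyridine as well (a number 0.60 log units higher from compound 1 to compound 4 (beyond the scatter)), just as it stood below compound 2.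

The step from compound 3 to compound 4 changes both the ring and its substituent at once, so the 5-chloropyridin-2-yl and 5-(trifluoromethyl)pyrimidin-2-yl groups would be needed to show how much of the rise belongs to each change. Nothing available here explains why these groups give such different numbers.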